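Exchanging the sulfur group on compound 2

A few compounds are considered here, and "the series" means these few. Any claim that something is new, unique, unknown or untested is made for them only; others in the source may bear on it.

Of the compounds shown here, two have been tested in a functional assay on the whole organism for antagonist activity, with Mus musculus as the target, in the maximal electroshock model; a lower number here means that less compound is needed, a higher number that more compound is needed for the effect. Compound 1 (`Cn1c(-c2cccs2)nnc1[S+](C)[O-]`) gives > 200 mg/kg, which is a limit of the assay and not a number. Compound 2 (`Cn1c(-c2ccccc2)nnc1[S+](C)[O-]`) gives > 100 mg/kg, which is likewise only a limit. Compound 2 therefore has no measured number in this assay, and neither does the other compound tested. Compound 3 (`CCS(=O)(=O)c1nnc(-c2ccccc2)n1C`) differs from compound 2 on an aromatic carbon of the five-membered ring, between two ring nitrogen atoms, where ethylsulfonyl enters: a group of 5 heavy atoms (2 carbon, 2 oxygen, 1 sulfur; no ring) in place of a group of 3 heavy atoms (1 carbon, 1 oxygen, 1 sulfur; no ring), on an aromatic carbon. Going by the values given here, no measured step shows what such a change does, so the expectation is loose. A modest shift towards less compound needed in this assay is expected, and the expected step is an at least 1.2-fold lower number from compound 2 to compound 3 (0.09 log units; that floor lies within the scatter). Compound 3 is estimated at 80 mg/kg, with an expected range from 25 mg/kg to 250 mg/kg.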

Compound 3, dose for half-maximal effect: > 200 mg/kg
Compound 3: no number, only a limit; the forecaster's own chance of this, stated with the estimate: 50%; at least 2.5-fold (0.39 log units) between middle value and limit.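

Compound 2 and compound 3 each stand only at a limit of this assay, so no step can be read between them. The compounds shown leave open what ethylsulfonyl in place of the smaller sulfur group does to the dose needed in this assay.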